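From a Cyclic Guanidine to a Piperazinone

A few compounds are considered here, and "the series" means these few. Any claim that something is new, unique, unknown or untested is made for them only; others in the source may bear on it.

In an assay on isolated protein for displacement of a labelled ligand from 5-hydroxytryptamine receptor 6 (Homo sapiens) (a higher number here means a weaker inhibitor, a lower number a stronger inhibitor), compound 1 `NC[C@@H]1CCCc2cc(S(=O)(=O)c3c[nH]c4ccccc34)ccc21` gives 0.0501 nM, compound 2 `CN(C[C@@H]1CCCc2cc(S(=O)(=O)c3cccc(F)c3)ccc21)S(N)(=O)=O` gives 3.98 nM, and compound 3 `O=C1CN=C(NC[C@@H]2CCCc3cc(S(=O)(=O)c4cccc(F)c4)ccc32)N1` gives 0.1 nM, a number close to that of compound 1 and far from that of compound 2. The step of a 40-fold lower number from compound 2 to compound 3 (1.60 log units; beyond the scatter) shows how strongly the group on this chain carbon sets the result. Compound 4 `O=C1CN(C[C@@H]2CCCc3cc(S(=O)(=O)c4cccc(F)c4)ccc32)CCN1` changes that group again: a group of 7 heavy atoms (4 carbon, 2 nitrogen, 1 oxygen; one six-membered non-aromatic ring with 2 hetero atoms) in place of a group of 7 heavy atoms (3 carbon, 3 nitrogen, 1 oxygen; one five-membered non-aromatic ring with 2 hetero atoms), on a saturated chain carbon bound to a saturated ring carbon. For the measured compounds named here, no measured step repeats this exact swap, so the outcome is uncertain, but because a 40-fold lower number from compound 2 to compound 3 (1.60 log units; beyond the scatter) shows wide swings from this position, a moderate shift toward a higher number is expected. Compound 4 is therefore estimated at 0.4 nM, between 0.08 nM and 2.5 nM, a step of a 4.0-fold higher number from compound 3 to compound 4 (0.60 log units; beyond the scatter).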

Compound 4, inhibition constant: 6.31 nM
Compound 4: middle estimate off by 16-fold (1.20 log units), on the low side; measured number outside the range, above it.
By their numbers in this assay, from the lowest: compounds 1 and 3 (each within the scatter of the next); then compounds 2 and 4 (each within the scatter of the next).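

In this assay, keeping the heavy-atom count the same on this saturated chain carbon does not keep the number the same: the entry of 3-oxopiperazin-1-yl gives a 63-fold higher number from compound 3 to compound 4 (1.80 log units; beyond the scatter) and ranks as a large step. Set against methyl(sulfamoyl)amino, the same group gives a 1.6-fold higher number from compound 2 to compound 4 (0.20 log units; within the scatter) and so reads alike, which shows that a ring on this carbon does not by itself bring a low number. Going by these compounds, how a plain piperazine without the carbonyl, or a simple amine, would read on the core of compound 4 stays open. Nothing available here accounts for the size of this gap.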